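Ring size at the amide nitrogen: estimate for compound 4

The compounds below may be only part of what the source reports. "The series", "measured", "known", "first", "only" and "open" are said of these compounds alone.

Measured compounds:
- Compound 1, `CC(C)=CCC/C(C)=C/CC/C(C)=C/CSC[C@H](NC(=O)CCCCCN1CCN(C)CC1)C(=O)NC1CCCCCC1`, gives 6200 nM in a functional assay on BXPC-3 cells (Homo sapiens) for cytotoxicity, read by fluorescence, with a stated time of 48 h; a higher number here means that more compound is needed for the effect, a lower number that less compound is needed.
- Compound 2, `CC(C)=CCC/C(C)=C/CC/C(C)=C/CSC[C@H](NC(=O)CCCCCN1CCN(C)CC1)C(=O)NC1CCCCCCC1`, gives 7500 nM in this assay.
- Compound 3, `CC(C)=CCC/C(C)=C/CC/C(C)=C/CSC[C@H](NC(=O)CCCCCN1CCCC1)C(=O)NC1CCCCCC1`, gives 5800 nM in this assay.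

The change in question is cyclooctyl in place of cycloheptyl on an amide-type nitrogen. Between the two measured compounds carrying it, the step is a 1.2-fold higher number from compound 1 to compound 2 (0.08 log units; within the scatter).

Compound 3 and compound 4 differ from compound 1 and compound 2 in their core: pyrrolidin-1-yl in place of 4-methylpiperazin-1-yl on a saturated chain carbon, five bonds along the chain from a carbonyl carbon. That change by itself made a step of a 1.1-fold lower number from compound 1 to compound 3 (0.03 log units; within the scatter). Compound 4, `CC(C)=CCC/C(C)=C/CC/C(C)=C/CSC[C@H](NC(=O)CCCCCN1CCCC1)C(=O)NC1CCCCCCC1`, has not yet been measured in this assay. The difference from compound 3 is cyclooctyl in place of cycloheptyl on an amide-type nitrogen. Among the compounds with values here, the place line is the same word for word as the one between compound 1 and compound 2, so the change is the same change, made on a core that differs only by the pyrrolidin-1-yl in place of the 4-methylpiperazin-1-yl.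

Within the data shown here, the only evidence for the change is the single step from compound 1 to compound 2, which lies within the scatter, and the core change from compound 1 to compound 3 also lies within the scatter. On that basis the step from compound 3 to compound 4 is expected to be a 1.2-fold higher number from compound 3 to compound 4 (0.08 log units; within the scatter) in this assay, in the same direction and of about the same small size. Compound 4 is therefore estimated at 7000 nM in this assay, with a range from 3500 nM to 14000 nM.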

Compound 4, half-maximal effective concentration: 4000 nM
Estimate against measurement, compound 4: 1.8-fold (0.24 log units) above; low and high end bracket the measured number.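

The swap of cycloheptyl for cyclooctyl on the amide-type nitrogen, read on the pyrrolidin-1-yl core in this assay, gives a 1.5-fold lower number from compound 3 to compound 4 (0.16 log units; within the scatter), and set beside the step on the 4-methylpiperazin-1-yl core it does not separate from it: the same change on two cores in this assay, a 1.2-fold higher number (0.08 log units; within the scatter) from compound 1 to compound 2 and a 1.5-fold lower number (0.16 log units; within the scatter) from compound 3 to compound 4, 1.8-fold (0.24 log units) apart, within the scatter of two such steps. The amine swap, now read on the cyclooctyl compounds as well, gives a 1.9-fold lower number from compound 2 to compound 4 (0.27 log units; within the scatter), and it too shows no dependence on the group at the amide-type nitrogen: the same change on two cores in this assay, a 1.1-fold lower number (0.03 log units; within the scatter) from compound 1 to compound 3 and a 1.9-fold lower number (0.27 log units; within the scatter) from compound 2 to compound 4, 1.8-fold (0.24 log units) apart, within the scatter of two such steps. So the four compounds are consistent with either change carrying from one core to the other without a detectable shift, but every step and both gaps lie within the scatter, which means neither a direction for either change nor any true additivity is shown, and a small interaction between the two places is not excluded.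

Still open, as far as these compounds go, is whether any group at the amide-type nitrogen, such as cyclohexyl, phenyl or an open-chain octyl, gives a step beyond the scatter in this assay. The same holds at the chain end for a morpholine or a dimethylamino group, and for a shorter chain, since these four compounds span too narrow a range to test transfer with any real step.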